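The source may report more compounds than this note shows. Statements on the series, on what has been measured and on what is new or still open speak of the compounds shown alone.

Three compounds have a measured value in an ADME assay on the whole organism for metabolic stability, with Rattus norvegicus as the target; a higher number here means that the compound lasts longer, a lower number that the compound disappears faster. Compound 1 `Fc1cnccc1-c1cc(-c2ccc(F)c(-c3ncccc3F)c2)cnn1` gives 0.8 h, compound 2 `Fc1cnc(-c2cc(-c3cnnc(-c4c(F)cncc4F)c3)ccc2F)c(F)c1` gives 1.6 h, and compound 3 `Fc1cnc(-c2cc(-c3ccc(F)c(-c4ncccc4F)c3)cnn2)c(F)c1` gives 10 h, the highest of the three numbers. Compound 4 `Fc1cnc(-c2cc(-c3ccc(F)c(-c4ncc(F)cc4F)c3)cnn2)c(F)c1` has not yet been measured. It differs from compound 3 in one place: fluoro in place of hydrogen on an aromatic carbon. Here fluoro takes the place of hydrogen on an aromatic carbon, so 3-fluoropyridin-2-yl becomes 3,5-difluoropyridin-2-yl.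

Among the compounds with values here, the one measured step that bears on this is a 13-fold higher number from compound 1 to compound 3 (1.10 log units; beyond the scatter), where 3,5-difluoropyridin-2-yl replaced 3-fluoropyridin-4-yl. That step is large, but it exchanges a whole group at a different place in the molecule, so it cannot set the size here. Compound 2 at 1.6 h also carries 3,5-difluoropyridin-2-yl, but it differs from compound 3 in more than one place. Within the data shown here, no measured pair isolates this single fluoro change. The estimate is therefore a 1.1-fold higher number from compound 3 to compound 4 (0.04 log units; within the scatter), and no step beyond the scatter is expected in this assay. The estimated value for compound 4 is 11 h, with an expected range from 4 h to 25 h.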

Compound 4, half-life: 53 h
For compound 4 the middle estimate is 4.8-fold (0.68 log units) below the measured one, and the stated range ends below it.
By their numbers in this assay, from the lowest: compounds 1 and 2 (each within the scatter of the next); then compound 3; then compound 4.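

Adding one fluoro, two atoms from the ring nitrogen and meta to a fluoro group, turns 3-fluoropyridin-2-yl into 3,5-difluoropyridin-2-yl and changes the result in this assay by a 5.3-fold higher number from compound 3 to compound 4 (0.72 log units; beyond the scatter), so this one position matters even though only a single heavy atom enters. The attachment of the ring matters as well, since 3,5-difluoropyridin-2-yl in place of 3,5-difluoropyridin-4-yl gives a 33-fold higher number from compound 2 to compound 4 (1.52 log units; beyond the scatter). Nothing measured here explains why either change lengthens the half-life.

Going by these compounds, whether chloro, methyl or methoxy at the same position would give a similar result remains open. On these data alone, it is also open whether this added fluoro would have a comparable effect in a compound carrying 3-fluoropyridin-4-yl, such as compound 1.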